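From 4-Methoxyphenyl to 3-Cyanophenyl on the Shared Core

The compounds below may be only part of what the source reports. "The series", "measured", "known", "first", "only" and "open" are said of these compounds alone.

Compound 1 `C=CCc1ccc(OCc2cn(-c3cccc([N+](=O)[O-])c3)nn2)c(O)c1` gives 58.8%
Compound 2 `C=CCc1ccc(OCc2cn(-c3ccc(OC)cc3)nn2)c(O)c1` gives 88.2%

In a functional assay on MIA PaCa-2 cells (Homo sapiens) for inhibition, read by MTT assay, with a stated time of 72 h, tested at 50 uM (a higher number here means more inhibition of growth at the concentration tested, a lower number less inhibition of growth), compound 2 stands highest of the two measured compounds at 88.2% and lies beyond the scatter from compound 1. Compound 3 `C=CCc1ccc(OCc2cn(-c3cccc(C#N)c3)nn2)c(O)c1` has 3-cyanophenyl in place of 4-methoxyphenyl on an aromatic nitrogen. For the measured compounds named here, compound 1 also lacks 4-methoxyphenyl, and its 58.8% in this assay is the only guide available. A fall beyond the scatter is therefore expected, an estimated a number 26.2 percentage points lower from compound 2 to compound 3 (beyond the scatter) in size. For compound 3 the expected value is 62% with an estimated range from 42% to 82% ( two compounds are thin ground ).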

Compound 3, percent growth inhibition at one concentration: 41.6%
Beside the measured number, compound 3's estimate is 20.4 percentage points above it; the whole stated range lies above it.
By their numbers in this assay, from the lowest: compound 3; then compound 1; then compound 2.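

In this assay, the group on the aromatic nitrogen has a large bearing on the result: 3-cyanophenyl in place of 4-methoxyphenyl gives a number 46.6 percentage points lower from compound 2 to compound 3 (beyond the scatter), the largest step shown. The group on the aromatic carbon also counts, since cyano in place of nitro gives a number 17.2 percentage points lower from compound 1 to compound 3 (beyond the scatter), so the two compounds without 4-methoxyphenyl are separated as well. Nothing available explains either step.

As far as these compounds go, whether the gain belongs to the methoxy group itself remains open. An unsubstituted phenyl, or an amine or carboxylic acid on that ring, could help to settle it.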